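A few compounds are considered here, and "the series" means these few. Any claim that something is new, unique, unknown or untested is made for them only; others in the source may bear on it.

Compound 1 `COc1ccc(Cn2cnc3c(N(C)c4ccc(OC)cc4)nc(Cl)nc32)cc1` gives > 100000 nM.
Compound 2 `COc1ccc(N(C)c2nc(Cl)nc3c2ncn3Cc2ccc(OC)c(OC)c2)cc1` gives 27000 nM.
Compound 3 `COc1ccc(Cn2cnc3c(Cl)ncnc32)cc1` gives > 50000 nM.

All three were tested in a functional assay on K562 cells (Homo sapiens) for antiproliferative activity, read by MTT assay, with a stated time of 48 h; on this read-out higher numbers stand for weaker inhibition of growth and lower numbers for stronger inhibition of growth. In this assay compound 1 gives > 100000 nM, which is a limit of the assay and not a number, as the limit of > 100000 nM in this assay, at which 1 of the 3 values shown sits, shows. Compound 2 gives 27000 nM. Compound 2 differs from compound 1 in one place, (methoxy in place of hydrogen on an aromatic carbon), and this change brought an at least 3.7-fold lower number from compound 1 to compound 2 (0.56 log units; beyond the scatter). Compound 3 carries the same core as compound 1 only in part; how the two cores differ is not broken down here. Compound 3 gives > 50000 nM, which is again a limit of the assay and not a number, as the limit of > 50000 nM in this assay, at which 1 of the 3 values shown sits, shows.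

Compound 4 `COc1ccc(Cn2cnc3c(Cl)ncnc32)cc1OC` has not yet been measured. It differs from compound 3 by methoxy in place of hydrogen on an aromatic carbon, the same change as between compound 1 and compound 2, in the same surroundings. The step from compound 3 to compound 4 is expected to be an at least 1.6-fold lower number from compound 3 to compound 4 (0.22 log units; that floor lies within the scatter), which rests on compound 1 and compound 2 having shown an at least 3.7-fold lower number from compound 1 to compound 2 (0.56 log units; beyond the scatter). Because compound 3 sits at a limit (the limit of > 50000 nM in this assay, at which 1 of the 3 values shown sits), the starting point of that step is itself uncertain. Compound 4 is therefore estimated at 30000 nM in this assay, expected to fall between 8000 nM and 120000 nM.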

Compound 4, concentration for 50% growth inhibition: > 50000 nM
Compound 4 was reported as a limit (the forecaster's own chance of this, stated with the estimate: 45%); middle value at least 1.6-fold (0.22 log units) away from the limit.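

Compound 3 and compound 4 both stand at a limit of this assay and not at a number, so no step between them can be read: the limit of > 50000 nM in this assay, at which 2 of the 4 values shown sit.

The compounds shown leave open whether methoxy in place of hydrogen on an aromatic carbon changes growth inhibition at all from compound 3 to compound 4, as it did from compound 1 to compound 2.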